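Acetylating the Amino Nitrogen of Compound 1

A few compounds are considered here, and "the series" means these few. Any claim that something is new, unique, unknown or untested is made for them only; others in the source may bear on it.

In a functional assay on MCF7 cells (Homo sapiens) for antiproliferative activity (a higher number here means a weaker inhibitor, a lower number a stronger inhibitor), compound 1 (`Nc1ccc(-c2nc3ccccc3s2)cc1Cl`) gives < 1 nM, which is a limit of the assay and not a number. Compound 2 (`Nc1ccc(-c2nc3ccccc3s2)cc1I`) gives < 1 nM, also a limit. The evidence so far is the limit of < 1 nM in this assay, at which 2 of the 2 values shown sit. Going by the values given here, the only measured step is a step that the two limits leave unreadable from compound 1 to compound 2, with iodo in place of chloro on an aromatic carbon, so it offers no size to carry over to a change elsewhere. Compound 3 (`CC(=O)Nc1ccc(-c2nc3ccccc3s2)cc1Cl`) has acetyl in place of hydrogen on a nitrogen on an aromatic ring, amino to acetamido: acetyl in place of hydrogen on a nitrogen on an aromatic ring. Among the compounds with values here, no measured step covers this change, so a modest weakening in this assay is only a cautious expectation, and a result at the same limit would remain possible. The expected change is an at least 3.0-fold higher number from compound 1 to compound 3 (0.47 log units; beyond the scatter). For compound 3 the estimated value is 3 nM, with an expected range from 0.5 nM to 50 nM.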

Compound 3, half-maximal inhibitory concentration: > 10 nM
Compound 3: only a limit was reported; the forecaster's own chance of this, stated with the estimate: 35%; middle value at least 3.3-fold (0.52 log units) from the limit.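

In this assay, acetyl in place of hydrogen on a nitrogen on an aromatic ring gives an at least 10-fold higher number from compound 1 to compound 3 (1.00 log units; beyond the scatter), the first step shown with a readable direction and a lower bound on its size. The step from chloro to iodo cannot be read, so the amino nitrogen is the only place shown where a change is known to weaken the compound. Compound 3 gives > 10 nM, which is a limit and not a number, so the step has no upper bound.

From the compounds shown here alone, it remains open whether this weakening belongs to acetyl itself or would also follow from another group on this nitrogen, such as methyl or a longer acyl chain like butanoyl. Going by these compounds, it is equally open whether acetyl on the nitrogen of compound 2 would give a step of similar size.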